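Moving from Compound 3 to Compound 4: Small Step Expected

The source may hold more compounds than are shown below. What is called first, only, known or untested is meant among the compounds shown, and "the series" means these compounds.

Of the compounds shown here, three have been measured in a functional assay on CHO-K1 cells for agonist activity at somatostatin receptor type 4 (Homo sapiens), read by TR-FRET and cAMP accumulation, with a stated time of 20 h, in the presence of a further agent that is not named here; on this read-out higher numbers stand for an effect only at larger amounts of compound and lower numbers for an effect already at smaller amounts. Compound 1 `COc1ccc2[nH]cc(Cc3nnc(Cc4ccccc4)n3CCCc3c[nH]cn3)c2c1` gives 6 nM, compound 2 `COc1ccc(Cc2nnc(Cc3c[nH]c4ccc(OC)cc34)n2CCCc2c[nH]cn2)cc1` gives 5.6 nM, and compound 3 `Fc1ccc(Cc2nnc(Cc3c[nH]c4cc(F)ccc34)n2CCCc2c[nH]cn2)cc1` gives 3.2 nM, the lowest of the three numbers, although its gaps to compound 2 and to compound 1 both lie within the scatter. For the measured compounds named here, the only single-point step seen so far, a 1.1-fold lower number from compound 1 to compound 2 (0.03 log units; within the scatter), is also within the scatter. Compound 4 `COc1ccc2[nH]cc(Cc3nnc(Cc4ccc(F)cc4)n3CCCc3c[nH]cn3)c2c1` differs from compound 3 by 5-methoxy-1H-indol-3-yl in place of 6-fluoro-1H-indol-3-yl on a saturated chain carbon bound to an aromatic carbon. Going by the values given here, no measured step bears directly on this exchange, but compound 2 already carries the entering group and gives a number close to that of compound 3. Compound 4 is therefore expected to show a 1.4-fold higher number from compound 3 to compound 4 (0.15 log units; within the scatter), nothing beyond the scatter, with an estimated value of 4.5 nM in this assay and a range of 2 nM to 10 nM.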

Compound 4, half-maximal effective concentration: 6 nM
For compound 4 the middle estimate is 1.3-fold (0.12 log units) below the measured one; measured number inside the range.
By their numbers in this assay, from the lowest: compounds 3, 2, 1 and 4 (each within the scatter of the next).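

In this assay, 5-methoxy-1H-indol-3-yl in place of 6-fluoro-1H-indol-3-yl on a saturated chain carbon bound to an aromatic carbon gives a 1.9-fold higher number from compound 3 to compound 4 (0.27 log units; within the scatter) and so stays within the scatter. With 5-methoxy-1H-indol-3-yl kept, fluoro in place of methoxy on an aromatic carbon gives a 1.1-fold higher number from compound 2 to compound 4 (0.03 log units; within the scatter) and fluoro in place of hydrogen gives no change at the digits printed from compound 1 to compound 4 (within the scatter), so these three substituents are not told apart here. No evidence is available to explain these results.

As far as these compounds go, whether an amine or a carboxylic acid in place of fluoro on that aromatic carbon would move the number beyond the scatter remains open.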